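A few compounds are considered here, and "the series" means these few. Any claim that something is new, unique, unknown or untested is made for them only; others in the source may bear on it.

Working notes on the cytotoxicity series. Compound 1 `CCOC(=O)CCCCCOc1cccc(CN(C(=O)c2ccc(-c3ccco3)cc2)C(C)C)c1` carries furan-2-yl at the varied position. In an ADME assay on BJ cells (Homo sapiens) for cytotoxicity, read by CellTiter-Glo and resazurin assay, with a stated time of 72 h (on this read-out lower numbers stand for an effect already at smaller amounts and higher numbers for an effect only at larger amounts of compound), compound 1 gives > 26000 nM, which is a limit of the assay and not a number. Compound 2 `CCOC(=O)CCCCCOc1cccc(CN(C(=O)c2ccc(-c3ccc(C(C)=O)s3)cc2)C(C)C)c1` carries 5-acetylthiophen-2-yl instead. In this assay compound 2 gives > 26000 nM, again only a limit. Compound 3 `CCOC(=O)CCCCCOc1cccc(CN(C(=O)c2ccc(-c3ccc4[nH]ccc4c3)cc2)C(C)C)c1` carries 1H-indol-5-yl. In this assay compound 3 gives > 26000 nM, also a limit. Among the compounds with values here, compound 3 thus stands exactly where every value measured so far stands, namely at the limit of > 26000 nM in this assay, at which 3 of the 3 values shown sit. The steps a step that the two limits leave unreadable from compound 1 to compound 2, a step that the two limits leave unreadable from compound 1 to compound 3 and a step that the two limits leave unreadable from compound 2 to compound 3 are each of a size the two limits leave unreadable, so none of them tells how far a change at this carbon can move the read-out.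

Compound 4 `CCOC(=O)CCCCCOc1cccc(CN(C(=O)c2ccc(-c3cccc([N+](=O)[O-])c3)cc2)C(C)C)c1` brings the change (3-nitrophenyl in place of 1H-indol-5-yl on an aromatic carbon). Within the data shown here, no measured step bears readably on it; the three aryl groups tried so far all sit at the same limit, and 3-nitrophenyl is a fourth group of the same size class. The step that the limit leaves unreadable from compound 3 to compound 4 is therefore expected to be none beyond the scatter, with the outcome most likely once more a limit rather than a number. Compound 4 is expected at 35000 nM, in a range from 12000 nM to 100000 nM.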

Compound 4, half-maximal effective concentration: < 1.3 nM
Compound 4: no number, only a limit; the forecaster's own chance of this, stated with the estimate: 80%; middle value at least 26000-fold (4.43 log units) away from the limit.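

In this assay this aromatic carbon, silent until now, turns out to be able to move the read-out, as 3-nitrophenyl in place of 1H-indol-5-yl shows (an at least 20000-fold lower number from compound 3 to compound 4 (4.30 log units; beyond the scatter)), and the same holds against the other two groups (an at least 20000-fold lower number from compound 2 to compound 4 (4.30 log units; beyond the scatter); an at least 20000-fold lower number from compound 1 to compound 4 (4.30 log units; beyond the scatter)). Size by heavy-atom count does not separate the change, since 1H-indol-5-yl and 3-nitrophenyl both have 9 heavy atoms, while the entering group has one aromatic ring in place of two, no hydrogen-bond donor and 2 hydrogen-bond acceptors. Of the four groups at this carbon, only 3-nitrophenyl leaves the upper limit, and compound 4 stands alone at the other end of the range: the limit of < 1.3 nM in this assay, at which 1 of the 4 values shown sits.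

On these data alone, both ends of these steps are limits, so the true size of the change stays open, as does the question of whether a phenyl carrying an amine or a nitrile in place of the nitro group would keep any of the effect. Also open, as far as these compounds go, is whether the effect survives with a carboxylic acid in place of the ethyl ester on the chain of the shared core.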